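Changing the Amide Aryl Group on a Benzothiazolyl Thioether Scaffold

The compounds below may be only part of what the source reports. "The series", "measured", "known", "first", "only" and "open" are said of these compounds alone.

Measured so far:
Compound 1, `COc1c(Br)cccc1C(=O)Nc1ccc(Sc2nc3ccccc3s2)c(Cl)c1`: > 100000 nM
Compound 2, `COc1ccc(Br)cc1C(=O)Nc1ccccc1`: > 100000 nM
Compound 3, `O=C(Nc1ccc(Sc2nc3ccccc3s2)cc1)c1ccccc1`: > 100000 nM

All three compounds were tested in an assay for inhibition of HSP60/HSP10 (Homo sapiens), with a stated time of 60 min; on this read-out lower numbers stand for stronger inhibition and higher numbers for weaker inhibition. In this assay compound 1 gives > 100000 nM, which is a limit of the assay and not a number. Compound 2 gives > 100000 nM, again a limit. Compound 3 gives > 100000 nM, also a limit. So compound 1 stands nowhere in particular among the numbers shown: all three values rest at the limit of > 100000 nM in this assay, at which 3 of the 3 values shown sit, and no ordering between them can be drawn. No pair of these compounds differs in only one place, so no measured step is available to guide the next change.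

The new compound is compound 4, `O=C(Nc1ccc(Sc2nc3ccccc3s2)c(Cl)c1)c1cc(Br)cc(Br)c1`. It is built from compound 1 by a change on the amide side: a group of 8 heavy atoms (6 carbon, 2 bromine; one six-membered aromatic ring of carbon only) in place of a group of 9 heavy atoms (7 carbon, 1 oxygen, 1 bromine; one six-membered aromatic ring of carbon only), on a carbonyl carbon. The shared core of compound 1 otherwise stays as it is.

Within the data shown here, since compound 1 sits at the limit in this assay and no measured step exists, no direction for the step can be read from the data; the expectation is simply that compound 4 will behave like compound 1 and stay at the limit, so the expected step that the limit leaves unreadable from compound 1 to compound 4 is none beyond the scatter. Compound 4 is therefore expected to give about 150000 nM in this assay, within a range of 30000 nM to 600000 nM.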

Compound 4, half-maximal inhibitory concentration: > 100000 nM
Compound 4 ended at the assay's limit; the forecaster's own chance of this, stated with the estimate: 80%; the middle value is on the limit's open side.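

The step from compound 1 to compound 4 cannot be read, since in this assay both compounds give a limit and not a number, as do the other compounds shown: the limit of > 100000 nM in this assay, at which 4 of the 4 values shown sit.

The compounds shown leave open which change to the shared core, if any, would give a measurable value in this assay.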